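Hydrogen for methyl on the amine of compound 2

This account rests on a few compounds, and the source may have more. Where it says the series, first, only, none or still open, it means among the compounds named here.

Within the data shown here, in a functional assay on HeLa cells (Homo sapiens) for antiproliferative activity, read by MTT assay, with a stated time of 48 h (a higher number here means a weaker inhibitor, a lower number a stronger inhibitor), compound 2 (`CNCC(=O)Nc1cc(OC)ccc1C(=O)c1cc(OC)c(OC)c(OC)c1`) reads 690 nM and holds the lower of the two numbers so far. Among the measured compounds shown here, compound 1 (`COc1ccc(C(=O)c2ccc(OC)c3c2C=CC(C)(C)O3)c(NC(=O)CBr)c1`) reads 3680 nM in the same test, a gap beyond the scatter, but the two compounds differ in more than one place and no single-change step links them. Compound 3 (`COc1ccc(C(=O)c2cc(OC)c(OC)c(OC)c2)c(NC(=O)CN)c1`) follows compound 2 except for hydrogen in place of methyl on an amine nitrogen, which turns methylamino to amino. For the measured compounds named here, no measured pair shows this change, so the expectation rests only on compound 2 at 690 nM as the starting point. The expected step is a 1.5-fold lower number from compound 2 to compound 3 (0.19 log units; within the scatter) in this assay and points to a lower number, though it may stay within the scatter. Compound 3 is estimated at 450 nM (expected range 120 nM to 1500 nM).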

Compound 3, half-maximal inhibitory concentration: 130 nM
The estimate for compound 3 lay 3.5-fold (0.54 log units) above the measured number; low and high end bracket the measured number.
By their numbers in this assay, from the lowest: compound 3; then compound 2; then compound 1.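

Hydrogen in place of methyl on the amine nitrogen gives a 5.3-fold lower number from compound 2 to compound 3 (0.72 log units; beyond the scatter) in this assay and is the first single-place step in the series. The earlier compounds shown here could not isolate this position, whereas this pair shows that one methyl on the nitrogen is enough to shift the number beyond the scatter, with the amino end reading lower than the methylamino end. No measured evidence on hand bears on the reason for this step.

On these data alone, the finding rests on a single pair, so it remains open whether the direction holds for other groups on this nitrogen, such as ethyl or a second methyl. Also open, as far as these compounds go, is whether a longer chain between the carbonyl and the amine would preserve the lower number of compound 3.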